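The source may report more compounds than this note shows. Statements on the series, on what has been measured and on what is new or still open speak of the compounds shown alone.

Measured so far:
compound 1, `COc1ccc2c(c1)C(=O)C=CC2=O`: 22700 nM
compound 2, `O=C1C=C(Oc2cccs2)C(=O)c2ccccc21`: 35300 nM

In a functional assay on HeLa cells (Homo sapiens) for cytotoxicity (on this read-out higher numbers stand for weaker inhibition and lower numbers for stronger inhibition), compound 1 gives 22700 nM, while compound 2 gives 35300 nM; the two numbers lie within the scatter of each other, so neither compound stands apart from the other. Compound 3, `CS(=O)(=O)Oc1ccc2c(c1)C(=O)C=CC2=O`, has not yet been measured. It differs from compound 1 in one place: methylsulfonyl in place of methyl on an oxygen on an aromatic ring. For the measured compounds named here, no step between measured compounds is known, so nothing here anchors the size of this change. The expected step is a 1.1-fold higher number from compound 1 to compound 3 (0.04 log units; within the scatter), no more than the scatter in either direction. Compound 3 is therefore estimated to give 25000 nM in this assay, within a range from 8000 nM to 80000 nM.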

Compound 3, half-maximal inhibitory concentration: 17700 nM
Estimate against measurement, compound 3: 1.4-fold (0.15 log units) above; measured number inside the range.
By their numbers in this assay, from the lowest: compounds 3, 1 and 2 (each within the scatter of the next).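

In this assay, methylsulfonyl in place of methyl on an oxygen on an aromatic ring gives a 1.3-fold lower number from compound 1 to compound 3 (0.11 log units; within the scatter) and so stays within the scatter. For the compounds shown here, this is the first step read at this position, and it shows that the number holds when the small methyl gives way to the larger methylsulfonyl, which brings hydrogen-bond acceptors with it. No measured evidence here accounts for this result. As far as these compounds go, whether a longer chain on this oxygen, or an amine or a carboxylic acid at this place, would move the number beyond the scatter remains open.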